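The source may report more compounds than this note shows. Statements on the series, on what has been measured and on what is new or still open speak of the compounds shown alone.

Compound 1 `CCN(c1ccccc1C)S(=O)(=O)c1cc(Cl)ccc1Cl`: > 25000 nM
Compound 2 `CCN(c1ccccc1)S(=O)(=O)c1cc(Cl)ccc1Cl`: > 5000 nM

In an ADME assay on A549 cells (Homo sapiens) for cytotoxicity, read by MTT assay (a higher number here means that more compound is tolerated, a lower number that less compound is tolerated), compound 1 gives > 25000 nM, which is a limit of the assay rather than a measured number. In this assay compound 2 gives > 5000 nM, again only a limit. The step that the two limits leave unreadable from compound 1 to compound 2 therefore cannot be read in size, as the limit of > 25000 nM in this assay, at which 1 of the 2 values shown sits, and the limit of > 5000 nM in this assay, at which 1 of the 2 values shown sits, make plain; all that the two values show is that both compounds are tolerated up to their limits.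

Compound 3 `CCN(c1ccccc1Cl)S(=O)(=O)c1cc(Cl)ccc1Cl` differs from compound 2 by chloro in place of hydrogen on an aromatic carbon. Going by the values given here, no measured step mirrors this change, and the one step that is recorded is unreadable, so compound 3 is expected to stand close to compound 2 in this assay, with no step beyond the scatter: a step that the limit leaves unreadable from compound 2 to compound 3. Compound 3 is estimated at 20000 nM, with a range from 5000 nM to 60000 nM, and most likely the assay again reports only a limit.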

Compound 3, half-maximal cytotoxic concentration: > 5000 nM
Compound 3 was reported as a limit (the forecaster's own chance of this, stated with the estimate: 70%); the middle value does not contradict the limit.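

In this assay, going by these compounds alone, compound 1, compound 2 and compound 3 are all reported only as limits, so no step among them can be read. The compounds shown leave open at what concentration any of them would start to harm these cells.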